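A few compounds are considered here, and "the series" means these few. Any claim that something is new, unique, unknown or untested is made for them only; others in the source may bear on it.

Compound 1, `Nc1scc(CN2CCN(c3cccc(Cl)c3Cl)CC2)c1C(=O)c1ccc(Cl)cc1`, is the reference point of this short series. In a functional assay on CHO cells with adenosine receptor A1 (Homo sapiens) as the target, read by cAMP accumulation and immunoassay, with a stated time of 6 min, tested at 0.01 uM (a lower number here means a stronger effect, a higher number a weaker effect of the compound at the concentration tested), compound 1 gives 1%. Two close relatives have been measured in this assay as well: compound 2, `COc1ccc(N2CCN(Cc3csc(N)c3C(=O)c3ccc(Cl)cc3)CC2)cc1`, gives -1.2%, and compound 3, `Nc1scc(CN2CCN(c3cccc(C(F)(F)F)c3)CC2)c1C(=O)c1ccc(Cl)cc1`, gives -8.2%. Compound 1 holds the highest of the three numbers, yet the distances are small: the nearest is compound 2, with a number 2.2 percentage points lower from compound 1 to compound 2 (within the scatter), and the furthest is compound 3, with a number 9.2 percentage points lower from compound 1 to compound 3 (within the scatter). The remaining pair behaves the same way, with a number 7 percentage points lower from compound 2 to compound 3 (within the scatter). None of these steps goes beyond the scatter, so the three compounds cannot be told apart on this read-out.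

Compound 4, `Nc1scc(CN2CCN(c3ccc(OC(F)(F)F)cc3)CC2)c1C(=O)c1ccc(Cl)cc1`, has not yet been measured. Compared with compound 1 the change is 4-(trifluoromethoxy)phenyl in place of 2,3-dichlorophenyl on an amine nitrogen in a ring. All three measured steps concern exactly this position, the aromatic group on the ring nitrogen, and each of them stayed within the scatter. The expected step is therefore a number 3 percentage points lower from compound 1 to compound 4 (within the scatter), meaning none beyond the scatter. Compound 4 is thus estimated to give -2% in this assay, with a range from -12% to 8%.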

Compound 4, a percentage reported as activity, at one concentration (the size of the read-out at that concentration, not a potency): 0%
Compound 4: middle estimate off by 2 percentage points, on the low side; the measured number falls inside the stated range.
By their numbers in this assay, from the lowest: compounds 3, 2, 4 and 1 (each within the scatter of the next).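

Compound 4 extends the range of groups on the amine nitrogen in the ring: 4-(trifluoromethoxy)phenyl brings oxygen and fluorine where 2,3-dichlorophenyl carries chlorine, yet this assay shows only a number 1 percentage points lower from compound 1 to compound 4 (within the scatter). The comparison with the other trifluorinated group gives a number 8.2 percentage points higher from compound 3 to compound 4 (within the scatter), and the narrowest change in the set, trifluoromethyl in place of methyl on an oxygen on an aromatic ring, gives a number 1.2 percentage points higher from compound 2 to compound 4 (within the scatter), so neither this exchange on the oxygen nor the change of aromatic group separates these compounds on this read-out. No measurement available here offers an explanation for how closely these numbers sit.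

All four compounds share an aromatic ring on this nitrogen and the same remaining structure, so the compounds shown leave open whether the read-out would stay as flat with a phenyl ring carrying a carboxylic acid or an amine, or with a cyclohexyl group or a longer alkyl chain in its place. Because the read-out comes from a single concentration, it also leaves open how the potencies of these compounds compare.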